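This account rests on a few compounds, and the source may have more. Where it says the series, first, only, none or still open, it means among the compounds named here.

Measured so far:
compound 1, `Cc1cc(NC(=O)Nc2ccc(C(=O)O)cc2)c2ccccc2n1`, 9300 nM
compound 2, `Cc1cc(NC(=O)Nc2ccc(C(=O)O)c(O)c2)c2ccccc2n1`, 26600 nM

These two compounds share a core and were both tested in a physicochemical assay for solubility, at pH 7.4; a higher number here means a more soluble compound, a lower number a less soluble compound. Compound 1 gives the lower of the two numbers; its nearest neighbour is compound 2, and the change from one to the other is a 2.9-fold higher number from compound 1 to compound 2 (0.46 log units; beyond the scatter), made by putting hydroxy in place of hydrogen on an aromatic carbon.

Compound 3, `CCc1ccc(NC(=O)Nc2cc(C)nc3ccccc23)cc1`, has not yet been measured in this assay. It differs from compound 1 in one place: ethyl in place of carboxy on an aromatic carbon. Among the measured compounds shown here, no measured step touches the carboxy group or adds an ethyl group, so the single step from compound 1 to compound 2 speaks only indirectly; it shows that one change on that ring shifted this assay by a modest, real amount, and says nothing about the direction for the change at hand. On general grounds, a step downward is expected, a 9.3-fold lower number from compound 1 to compound 3 (0.97 log units; beyond the scatter), but with wide uncertainty. Compound 3 is therefore estimated at 1000 nM, in a range from 150 nM to 6000 nM.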

Compound 3, solubility: 3300 nM
Compound 3: the middle estimate sits 3.3-fold (0.52 log units) below what was measured; the range from low to high includes it.
By their numbers in this assay, from the lowest: compound 3; then compound 1; then compound 2.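

In this assay, among the compounds shown here, the step of a 2.8-fold lower number from compound 1 to compound 3 (0.45 log units; beyond the scatter) is the first measured change at the place held by the carboxy group, on an aromatic carbon para to a large group. It gives this position a direction that the hydroxy step could not give: replacing carboxy with ethyl lowers the number, while the step remains modest in size, and compound 3 still gives 3300 nM as a measured value. Nothing measured here explains why the number moves this way, so the step records an outcome and not a mechanism.

This single swap removes one group and adds another at the same time, so the compounds shown cannot separate what leaving carboxy contributes from what entering ethyl contributes. A plain hydrogen at this place would help to pull those two parts apart, and an amine, a primary amide, a methyl ester or a longer chain such as butyl would show whether the number in this assay follows any trend across different groups at this position.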